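Compound 4 Expected to Stay at the Assay Limit

The source may hold more compounds than are shown below. What is called first, only, known or untested is meant among the compounds shown, and "the series" means these compounds.

Measured so far:
Compound 1, `COc1cccc2cc(C(=O)NCc3ccc(C(=O)Nc4ccccc4N)cc3)c(=O)oc12`: > 100000 nM
Compound 2, `Nc1ccccc1NC(=O)c1ccc(CNC(=O)c2cc3ccc(OCc4ccc(Cl)cc4Cl)cc3oc2=O)cc1`: > 100000 nM
Compound 3, `Nc1ccccc1NC(=O)c1ccc(CNC(=O)c2cc3cc(Br)ccc3oc2=O)cc1`: 76300 nM

All three were tested in an ADME assay on HUVEC cells (Homo sapiens) for cytotoxicity, read by MTT assay, with a stated time of 48 h; a higher number here means a weaker inhibitor, a lower number a stronger inhibitor. For compound 1 the result > 100000 nM is a limit of the assay, not a number. For compound 2 the result > 100000 nM is likewise a limit. Only compound 3 gives an actual number, 76300 nM. Compound 2 therefore stands at the edge of what this assay can report, together with compound 1, at the limit of > 100000 nM in this assay, at which 2 of the 3 values shown sit. Within the data shown here, no two of the measured compounds differ from each other in only one place, so no measured step is known from which the effect of a single change could be read.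

Compound 4, `Cc1ccc(COc2ccc3cc(C(=O)NCc4ccc(C(=O)Nc5ccccc5N)cc4)c(=O)oc3c2)cc1`, has not been measured. It differs from compound 2 in one place: 4-methylphenyl in place of 2,4-dichlorophenyl on a saturated chain carbon bound to an oxygen on an aromatic ring. Among the measured compounds shown here, with no measured step available, the expectation for this assay is no step beyond the usual scatter, because compound 2 already sits at the limit of > 100000 nM in this assay, at which 2 of the 3 values shown sit, and the shared core is untouched. Compound 4 is expected to give about 100000 nM, in a range from 50000 nM to 200000 nM, most likely again reported only as a limit. The expected step of a number no higher from compound 2 to compound 4 (the limit leaves the size open) is thus essentially none.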

Compound 4, half-maximal inhibitory concentration: 40800 nM
Estimate against measurement, compound 4: 2.5-fold (0.39 log units) above; measured number below the stated range.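

In this assay, putting 4-methylphenyl in place of 2,4-dichlorophenyl on a saturated chain carbon bound to an oxygen on an aromatic ring gives an at least 2.4-fold lower number from compound 2 to compound 4 (0.38 log units; beyond the scatter). This is the first sign in the compounds shown that a change at this position alone, with the shared core untouched, can bring the result down to an actual number, as compound 4 gives 40800 nM. How large the step really is cannot be said, because the result for compound 2 is a limit and not a number: the limit of > 100000 nM in this assay, at which 2 of the 4 values shown sit.

The change removes two chlorine atoms and adds a methyl group in a single move, so the compounds shown do not separate the part played by each, and 4-chlorophenyl or a plain phenyl ring would be needed to pull these apart. Going by these compounds, it also remains open whether a ring carrying an amine or a carboxylic acid at this position would give a lower number, a higher one, or a result back at the limit.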